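Thiophene amide in place of the trifluoromethylphenyl amide

The source may report more compounds than this note shows. Statements on the series, on what has been measured and on what is new or still open speak of the compounds shown alone.

Compound 1 `COc1ccc(-c2cn3cc(C4=CCN(C(=O)c5ccccc5C(F)(F)F)CC4)ccc3n2)cc1OC` stands lowest of the three numbers in a functional assay on B16-F10 cells (Mus musculus) for antiproliferative activity, read by MTT assay, with a stated time of 48 h (on this read-out higher numbers stand for weaker inhibition and lower numbers for stronger inhibition), where compound 1 gives 8110 nM. Compound 2 `COc1ccc(-c2cn3cc(C4=CCN(C(=O)c5ccc(Cl)cc5)CC4)ccc3n2)cc1OC` gives 15300 nM and compound 3 `COc1ccc(-c2cn3cc(C4=CCN(S(=O)(=O)c5ccccc5)CC4)ccc3n2)cc1OC` gives 13200 nM. The gaps a 1.9-fold higher number from compound 1 to compound 2 (0.28 log units; within the scatter) and a 1.6-fold higher number from compound 1 to compound 3 (0.21 log units; within the scatter) are within the scatter, as is a 1.2-fold lower number from compound 2 to compound 3 (0.06 log units; within the scatter), so the three measured compounds cannot be separated on this assay.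

Compound 4 `COc1ccc(-c2cn3cc(C4=CCN(C(=O)c5cccs5)CC4)ccc3n2)cc1OC` differs from compound 1 in one place: thiophen-2-yl in place of 2-(trifluoromethyl)phenyl on a carbonyl carbon.

Within the data shown here, the steps that bear on this change are those altering the group on the carbonyl carbon or the whole group on the ring nitrogen: a 1.9-fold higher number from compound 1 to compound 2 (0.28 log units; within the scatter) and a 1.6-fold higher number from compound 1 to compound 3 (0.21 log units; within the scatter), both within the scatter. No change at this part of the molecule has so far produced a step beyond the scatter, and no thiophene occurs among the measured compounds, so the expectation rests on those two steps alone. A step within the scatter is therefore expected, a 1.2-fold higher number from compound 1 to compound 4 (0.09 log units; within the scatter). Compound 4 is estimated at 10000 nM, in the range 4000 nM to 25000 nM.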

Compound 4, half-maximal inhibitory concentration: 19500 nM
Compound 4: middle estimate off by 2.0-fold (0.29 log units), on the low side; the range from low to high includes it.
By their numbers in this assay, from the lowest: compounds 1, 3, 2 and 4 (each within the scatter of the next, the first and the last beyond it).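

In this assay, among these compounds, a change of the group on the carbonyl carbon now gives the first step beyond the scatter at this position, a modest one (a 2.4-fold higher number from compound 1 to compound 4 (0.38 log units; beyond the scatter)), with thiophen-2-yl in place of 2-(trifluoromethyl)phenyl. The other two new steps (a 1.5-fold higher number from compound 3 to compound 4 (0.17 log units; within the scatter)) and (a 1.3-fold higher number from compound 2 to compound 4 (0.11 log units; within the scatter)) lie within the scatter, so compound 4 separates from compound 1 alone, and the thiophene amide is set apart from neither the phenylsulfonyl group nor the 4-chlorophenyl amide. No measurement at hand accounts for the step from the trifluoromethylphenyl amide to the thiophene amide.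

Open, going by these compounds, is whether the gap follows the trifluoromethyl group or the change of ring, since the two differ together in this pair. Also open, on these data alone, is how an amine, a carboxylic acid or a longer alkyl chain on the carbonyl carbon would compare with compound 1.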